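This account rests on a few compounds, and the source may have more. Where it says the series, first, only, none or still open, it means among the compounds named here.

Measured compounds in the series:

compound 1, `CN1CCN(Cc2csc(N)c2C(=O)c2ccc(Cl)cc2)CC1`, in an assay on CHO cells for displacement of a labelled ligand from adenosine receptor A1 (Homo sapiens) (a higher number here means weaker binding, a lower number tighter binding), gives 1.2 nM
compound 2, `Nc1scc(CN2CCN(C3CCCCC3)CC2)c1C(=O)c1ccc(Cl)cc1`, in this assay gives 1.1 nM
compound 3, `Cc1ccc(N2CCN(Cc3csc(N)c3C(=O)c3ccc(Cl)cc3)CC2)cc1`, in this assay gives 1 nM

Compound 3 has the lowest of the three numbers, but the gaps are small: a 1.2-fold lower number from compound 1 to compound 3 (0.08 log units; within the scatter) and a 1.1-fold lower number from compound 2 to compound 3 (0.04 log units; within the scatter) are both within the scatter, so the three compounds are not separated on these data.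

The next compound, compound 4, `Nc1scc(CN2CCN(c3ncccn3)CC2)c1C(=O)c1ccc(Cl)cc1`, takes the same ring nitrogen one step further: pyrimidin-2-yl in place of 4-methylphenyl on an amine nitrogen in a ring.

Within the data shown here, every measured step so far touches exactly this position. a 1.1-fold lower number from compound 1 to compound 2 (0.04 log units; within the scatter), a 1.2-fold lower number from compound 1 to compound 3 (0.08 log units; within the scatter) and a 1.1-fold lower number from compound 2 to compound 3 (0.04 log units; within the scatter) cover methyl, cyclohexyl and 4-methylphenyl on the ring nitrogen, and none of them moves the number beyond the scatter. Among the measured compounds shown here, a pyrimidin-2-yl has not yet been tried here, and no measured step shows what a ring with hetero atoms at this place does, so the expectation rests on the three flat steps alone. No step beyond the scatter is therefore expected in this assay for compound 4, in either direction.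

The estimate for compound 4 in this assay is 1.3 nM, with a range from 0.5 nM to 3.5 nM, which is expected to mean a 1.3-fold higher number from compound 3 to compound 4 (0.11 log units; within the scatter).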

Compound 4, dissociation constant: 1.1 nM
Beside the measured number, compound 4's estimate is 1.2-fold (0.07 log units) above it; the range from low to high includes it.
By their numbers in this assay, from the lowest: compounds 3, 2, 4 and 1 (each within the scatter of the next).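

In this assay, among these compounds, pyrimidin-2-yl on the amine nitrogen in a ring gives a 1.1-fold higher number from compound 3 to compound 4 (0.04 log units; within the scatter), no change at the digits printed from compound 2 to compound 4 (within the scatter) and a 1.1-fold lower number from compound 1 to compound 4 (0.04 log units; within the scatter), so compound 4 cannot be separated from any of the earlier compounds. Among the compounds shown here, this is the first step at this position that brings in a six-membered aromatic ring with 2 hetero atoms and 2 hydrogen-bond acceptors, in place of the six-membered aromatic ring of carbon only in 4-methylphenyl with 0 hydrogen-bond acceptors, and the flat picture seen with methyl, cyclohexyl and 4-methylphenyl now extends to it, with no compound of the four going against it. Nothing available explains why these four groups cannot be told apart in this read-out.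

It remains open whether a carboxylic acid, a primary amine or a longer chain ending in a phenyl ring on this ring nitrogen would move the number beyond the scatter, or whether the flat picture holds only for the four groups shown. As far as these compounds go, all four compounds also keep the rest of the shared core unchanged, so what a change elsewhere, such as replacing the chlorine with a methoxy group, would do at this position stays unknown.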